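This account rests on a few compounds, and the source may have more. Where it says the series, first, only, none or still open, it means among the compounds named here.

Measured in a functional assay on K562 cells (Homo sapiens) for inhibition, with a stated time of 72 h; on this read-out higher numbers stand for weaker inhibition and lower numbers for stronger inhibition:
- Compound 1 `NC1CCC(Nc2nc(NCc3ccc(-c4ccco4)cc3)c3ncn(C4CCCC4)c3n2)CC1`: 96 nM
- Compound 2 `NC1CCC(Nc2nc(NCc3ccc(-c4ccsc4)cc3)c3ncn(C4CCCC4)c3n2)CC1`: 150 nM

Not yet measured:
- Compound 3 `CC(C)(O)CNc1nc(NCc2ccc(-c3ccco3)cc2)c2ncn(C3CCCC3)c2n1`

Going by the values given here, compound 1 cannot be told apart from compound 2, the only other measured compound: a 1.6-fold higher number from compound 1 to compound 2 (0.19 log units; within the scatter). Compound 3 differs from compound 1 at another place: 2-hydroxy-2-methylpropyl in place of 4-aminocyclohexyl on a nitrogen on an aromatic ring. Here, 2-hydroxy-2-methylpropyl replaces 4-aminocyclohexyl on a nitrogen on an aromatic ring. Among the compounds with values here, the one measured step swaps furan-2-yl for thiophen-3-yl on an aromatic carbon, so it cannot size this change, and the expectation remains uncertain. In this assay, the expected change is toward weaker inhibition, a 4.2-fold higher number from compound 1 to compound 3 (0.62 log units; beyond the scatter). Compound 3 is estimated at 400 nM, with a range of 120 nM to 1500 nM.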

Compound 3, half-maximal inhibitory concentration: 16800 nM
Compound 3: middle estimate off by 42-fold (1.62 log units), on the low side; the whole stated range lies below it.
By their numbers in this assay, from the lowest: compounds 1 and 2 (each within the scatter of the next); then compound 3.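

In this assay, the group on this nitrogen counts for much more than the earlier furan-2-yl to thiophen-3-yl swap, which stayed within the scatter: placing 2-hydroxy-2-methylpropyl where 4-aminocyclohexyl stood gives a 180-fold higher number from compound 1 to compound 3 (2.24 log units; beyond the scatter) as a large step toward weaker inhibition. This single change removes the six-membered ring and also replaces the nitrogen of the group with an oxygen, so the two differences cannot be separated here. Nothing available explains the loss. Still open, going by these compounds, is whether 4-hydroxycyclohexyl, which keeps the ring but carries a hydroxyl, or 2-amino-2-methylpropyl, an open chain with an amine, would retain the inhibition of compound 1.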